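Lengthening the Amide Chain of a Calpain Ketoamide

The compounds below may be only part of what the source reports. "The series", "measured", "known", "first", "only" and "open" are said of these compounds alone.

Of the compounds shown here, three have been measured in an assay on isolated protein (Oryctolagus cuniculus) for inhibition of Calpain-2 catalytic subunit (Homo sapiens), at pH 8.0; a lower number here means a stronger inhibitor, a higher number a weaker inhibitor. Compound 3 `CCCCNC(=O)C(=O)C(CC)NC(=O)C(CC(C)C)NC(=O)OCc1ccccc1` gives 50 nM, the lowest of the three numbers. Compound 1 `CCOC(=O)C(=O)C(CC)NC(=O)C(CC(C)C)NC(=O)C(c1ccccc1)c1ccccc1` gives 200 nM, and compound 2 `CCC(=O)C(=O)[C@H](CC)NC(=O)[C@H](CC(C)C)NC(=O)[C@H](CC(C)C)NC(=O)OCc1ccccc1` gives 2600 nM; both gaps to compound 3 lie beyond the usual scatter, so compound 3 is the strongest inhibitor of the three.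

Compound 4 `CCCCCCCCCCNC(=O)C(=O)C(CC)NC(=O)C(CC(C)C)NC(=O)OCc1ccccc1` has not yet been measured. It differs from compound 3 in one place: hexyl in place of hydrogen on a saturated chain carbon, four bonds along the chain from an amide-type nitrogen. Going by the values given here, none of the measured compounds shows how such a change acts in this assay, so the direction of the step is open. The expectation is a modest shift, not clearly beyond the scatter, as a 1.3-fold lower number from compound 3 to compound 4 (0.10 log units; within the scatter). Compound 4 is accordingly estimated at 40 nM, within a range from 12 nM to 130 nM.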

Compound 4, inhibition constant: 600 nM
Compound 4: the middle estimate sits 15-fold (1.18 log units) below what was measured; the whole stated range lies below it.
By their numbers in this assay, from the lowest: compound 3; then compound 1; then compound 4; then compound 2.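

Placing hexyl on a saturated chain carbon, four bonds along the chain from an amide-type nitrogen, is far from a neutral change in this assay: it gives a 12-fold higher number from compound 3 to compound 4 (1.08 log units; beyond the scatter). The step is large and lies beyond the scatter, so this position responds strongly to chain length, at least for this one pair. Nothing available explains the weaker inhibition.

Only these two chain lengths can be compared. Methyl, ethyl or propyl at this position could show whether the number rises gradually or abruptly, and a chain ending in a carboxylic acid remains unexplored.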